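The compounds below may be only part of what the source reports. "The series", "measured", "known", "first", "only" and "open" are said of these compounds alone.

Compound 1 `CCS(=O)(=O)NC(=O)c1ccc(Nc2nc(NC3(c4ccc(Cl)cc4)CC3)nc(OCC(F)(F)F)n2)cc1` is the starting point; in an ADME assay on microsomes from liver (Homo sapiens) for metabolic stability, with a stated time of 10 min (a lower number here means that less of the compound is left, a higher number that more of the compound is left), compound 1 gives 100%. In this assay, among the measured compounds shown here, compound 2 `CC(C)OC(=O)NCCS(=O)(=O)NC(=O)c1ccc(Nc2nc(NC3(c4ccc(Cl)cc4)CC3)nc(OCC(F)(F)F)n2)cc1` gives 100%, so the one measured step, no change at the digits printed from compound 1 to compound 2 (within the scatter), is flat. Compound 3 `CNC(=O)NCCS(=O)(=O)NC(=O)c1ccc(Nc2nc(NC3(c4ccc(Cl)cc4)CC3)nc(OCC(F)(F)F)n2)cc1` differs from compound 1 by (methylcarbamoyl)amino in place of hydrogen on a saturated chain carbon, two bonds along the chain from a sulfonyl sulfur. For the measured compounds named here, the only step that bears on it is that flat one, which alters the same saturated chain carbon two bonds along the chain from the sulfonyl sulfur, so no movement beyond the scatter is expected, and the step is estimated as no change at the digits printed from compound 1 to compound 3 (within the scatter). Compound 3 is therefore expected to give 100%, likely between 85% and 100%.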

Compound 3, percent of the compound remaining: 97%
Compound 3: middle estimate off by 3 percentage points, on the high side, and the stated range covers the measured number.
By their numbers in this assay, from the lowest: compounds 3, 1 and 2 (each within the scatter of the next).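

In this assay the step at the saturated chain carbon, two bonds along the chain from a sulfonyl sulfur, reads a number 3 percentage points lower from compound 1 to compound 3 (within the scatter) and so shows a second group, (methylcarbamoyl)amino with its 2 hydrogen-bond donors, leaving the reading flat. Methylamino in place of isopropoxy on the carbonyl carbon reads a number 3 percentage points lower from compound 2 to compound 3 (within the scatter) and shows that the end of the group can also be exchanged with no movement beyond the scatter.

On these data alone, whether a free amine, a carboxylic acid or a longer chain at this carbon would read the same stays open. Nothing shown here offers an explanation for these flat readings.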